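The source may hold more compounds than are shown below. What is called first, only, known or untested is meant among the compounds shown, and "the series" means these compounds.

In an assay on cells for inhibition of Nicotinamide N-methyltransferase (Homo sapiens), read by fluorescence and coupled enzyme assay, with a stated time of 10 min, in the presence of a further agent that is not named here (a lower number here means a stronger inhibitor, a higher number a weaker inhibitor), compound 2 `Nc1ncnc2c1ncn2[C@@H]1O[C@H](CN(CCCc2cccc3ccccc23)CC[C@H](N)C(=O)O)[C@@H](O)[C@H]1O` gives 11800 nM, the highest number of the three measured compounds. Compound 1 `Nc1ncnc2c1ncn2[C@@H]1O[C@H](CN(CCCc2cccc3ccccc23)CCC[C@H](N)C(=O)O)[C@@H](O)[C@H]1O`, which carries the longer 2-amino-2-carboxyethyl arm, gives 1100 nM in this assay, and compound 3 `COc1ccc(C(N)=O)cc1C#CCN(CC[C@H](N)C(=O)O)C[C@H]1O[C@@H](n2cnc3c(N)ncnc32)[C@H](O)[C@@H]1O` gives 52 nM. Within the data shown here, the only single-point step that has been measured is an 11-fold higher number from compound 1 to compound 2 (1.03 log units; beyond the scatter), which concerns the amino acid arm and not the aromatic group.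

Compound 4 `NC(=O)c1cccc(CCCCN(CC[C@H](N)C(=O)O)C[C@H]2O[C@@H](n3cnc4c(N)ncnc43)[C@H](O)[C@@H]2O)c1` differs from compound 2 in the aromatic group alone: 3-carbamoylbenzyl in place of naphthalen-1-yl on a saturated chain carbon, three bonds along the chain from an amine nitrogen. Among the measured compounds shown here, no measured pair isolates this exchange, so the step from compound 2 to compound 4 cannot be read off directly. What the data do show is that compound 3, which also carries an aromatic carboxamide on the same side of the amine nitrogen, gives 52 nM, far below compound 2. Its linker and ring substitution differ from those of compound 4, so only part of that gap can be carried over.

On this basis the change is expected to lower the number by a 7.9-fold lower number from compound 2 to compound 4 (0.90 log units; beyond the scatter). Compound 4 is therefore estimated at 1500 nM in this assay, with a likely range from 300 nM to 8000 nM.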

Compound 4, inhibition constant: 840 nM
Compound 4: the middle estimate sits 1.8-fold (0.25 log units) above what was measured; low and high end bracket the measured number.
By their numbers in this assay, from the lowest: compound 3; then compounds 4 and 1 (each within the scatter of the next); then compound 2.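

Among these compounds, exchanging naphthalen-1-yl for 3-carbamoylbenzyl in this assay gives a 14-fold lower number from compound 2 to compound 4 (1.15 log units; beyond the scatter), the first measured step at the aromatic end of the molecule, as the earlier step concerned only the amino acid arm. It shows that the group on a saturated chain carbon, three bonds along the chain from an amine nitrogen, strongly affects the number, and that two six-membered aromatic rings are not needed there for the stronger result. The exchange alters several things at once, removing one aromatic ring and adding a carboxamide with its hydrogen-bond donor and acceptor, and nothing available explains why the number falls.

The compounds shown leave open whether the drop comes from the smaller ring system or from the carboxamide, a question that an unsubstituted benzyl group or a carboxylic acid in place of the carboxamide could help to separate. They also leave open whether 3-carbamoylbenzyl and the longer 2-amino-2-carboxyethyl arm of compound 1 would add together on one molecule.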